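Three inactive sulfonamide hydrazides and a predicted fourth

The source may hold more compounds than are shown below. What is called first, only, known or untested is meant among the compounds shown, and "the series" means these compounds.

Compound 1 `Cc1ccccc1NNC(=O)c1cccc(NS(=O)(=O)c2cnc(O)nc2O)c1` — in a functional assay on SGC-7901 cells (Homo sapiens) for antiproliferative activity, read by MTT assay, with a stated time of 24 h (a higher number here means a weaker inhibitor, a lower number a stronger inhibitor), compound 1 gives > 20000 nM, a limit of the assay.
Compound 2 `Cc1cccc(NNC(=O)c2cccc(NS(=O)(=O)c3cnc(O)nc3O)c2)c1` — in this assay compound 2 gives > 20000 nM, again a limit.
Compound 3 `Cc1ccccc1NNC(=O)c1ccccc1NS(=O)(=O)c1cnc(O)nc1O` — in this assay compound 3 gives > 20000 nM, also a limit.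

For the measured compounds named here, all three values sit at the limit of > 20000 nM in this assay, at which 3 of the 3 values shown sit, so no compound can be ranked against another. The change from compound 1 to compound 2 is 3-methylphenyl in place of 2-methylphenyl on an amine nitrogen; its step, a step that the two limits leave unreadable from compound 1 to compound 2, cannot be read because both values are limits. The difference between the core of compound 1 and the core of compound 3 is not broken down here.

Compound 4 `Cc1cccc(NNC(=O)c2ccccc2NS(=O)(=O)c2cnc(O)nc2O)c1` carries the same change on the core of compound 3: 3-methylphenyl in place of 2-methylphenyl on an amine nitrogen. Since the earlier step stayed unreadable and compound 3 itself is at a limit, the expected step that the limit leaves unreadable from compound 3 to compound 4 is small, and compound 4 is estimated at 30000 nM in this assay, most likely reported only as a limit.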

Compound 4, half-maximal inhibitory concentration: > 20000 nM
Compound 4 was reported as a limit; the forecaster's own chance of this, stated with the estimate: 85%; the middle value does not contradict the limit.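

For the compounds shown here, compound 3 and compound 4 both stand at a limit of the assay, so no step between them can be read: the limit of > 20000 nM in this assay, at which 4 of the 4 values shown sit.

The four compounds leave open whether 3-methylphenyl in place of 2-methylphenyl, or the difference between the cores of compound 1 and compound 3, changes antiproliferative activity at all.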